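The source may hold more compounds than are shown below. What is called first, only, known or untested is meant among the compounds shown, and "the series" means these compounds.

Measured in a physicochemical assay for solubility, read by turbidimetry, measured as kinetic solubility, at pH 6.8; a lower number here means a less soluble compound, a higher number a more soluble compound:
- compound 1 `Cc1ccnc(N2C(=O)CSC2c2cccc(C(=O)NCCCCn3cccn3)c2)c1`: 50000 nM
- compound 2 `O=C(NCCCCc1ccccc1)c1cccc(C2SCC(=O)N2c2cccc(-c3c[nH]nn3)c2)c1`: 20000 nM

In this assay compound 2, at 20000 nM, holds the lower of the two numbers, and its gap to compound 1 lies beyond the scatter. Compound 3 `O=C(NCCCCc1ccccc1)c1cccc(C2SCC(=O)N2c2ccc(C3CC3)cc2)c1` differs from compound 2 on an amide-type nitrogen in a ring: a group of 9 heavy atoms (9 carbon; one three-membered non-aromatic ring of carbon only, one six-membered aromatic ring of carbon only) in place of a group of 11 heavy atoms (8 carbon, 3 nitrogen; one five-membered aromatic ring with 3 hetero atoms, one six-membered aromatic ring of carbon only), on an amide-type nitrogen in a ring. Within the data shown here, no two measured compounds differ in one place only, so no measured step sizes this change. A lower number is expected, beyond the scatter, with an estimated 4.0-fold lower number from compound 2 to compound 3 (0.60 log units; beyond the scatter). Compound 3 is estimated at 5000 nM, with an expected range of 1000 nM to 15000 nM.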

Compound 3, solubility: 2000 nM
For compound 3 the middle estimate is 2.5-fold (0.40 log units) above the measured one; low and high end bracket the measured number.
By their numbers in this assay, from the lowest: compound 3; then compound 2; then compound 1.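

In this assay, among these compounds, the group on the amide-type nitrogen in a ring proves to matter: 4-cyclopropylphenyl in place of the group with a five-membered aromatic ring with 3 hetero atoms gives a 10-fold lower number from compound 2 to compound 3 (1.00 log units; beyond the scatter) as the only single-place step here. Hydrogen-bond donors and acceptors are lost along with that ring, so this one step cannot separate the two. Nothing measured bears on the reason for the drop.

Going by these compounds, how a 4-aminophenyl or 4-carboxyphenyl group would read at this place remains open. So does whether the step holds alongside the pyrazole-bearing butyl chain of compound 1.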